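Methoxy in Place of Methyl: An Expected Step

A few compounds are considered here, and "the series" means these few. Any claim that something is new, unique, unknown or untested is made for them only; others in the source may bear on it.

Compound 2 `Cc1ccc(-c2nn(-c3ccccc3)cc2C(=O)NOCc2ccccc2)cc1` stands second highest of three numbers in an ADME assay on HEK-293T cells (Homo sapiens) for antiproliferative activity, read by MTT assay, with a stated time of 48 h, in the presence of a further agent that is not named here (on this read-out lower numbers stand for higher toxicity in this test and higher numbers for lower toxicity in this test), where compound 2 gives 40800 nM. Compound 1 `O=C(NOCc1ccccc1)c1cn(-c2ccccc2)nc1-c1ccccc1` gives 122000 nM, and compound 3 `Cc1ccc(-c2nn(-c3ccccc3)cc2C(=O)NOCc2ccc(Cl)cc2Cl)cc1` gives 39600 nM. The step of a 3.0-fold lower number from compound 1 to compound 2 (0.48 log units; beyond the scatter) came with methyl in place of hydrogen on an aromatic carbon, while a 1.0-fold lower number from compound 2 to compound 3 (0.01 log units; within the scatter) came with 2,4-dichlorophenyl in place of phenyl on a saturated chain carbon bound to an oxygen. Compound 4 `COc1ccc(-c2nn(-c3ccccc3)cc2C(=O)NOCc2ccccc2)cc1` differs from compound 2 by methoxy in place of methyl on an aromatic carbon. Only the first of these steps touches the same position, and it added a group rather than exchanging one, so a step of a 1.0-fold lower number from compound 2 to compound 4 (0.01 log units; within the scatter) is expected, not beyond the scatter. Compound 4 is therefore estimated at 40000 nM, between 15000 nM and 110000 nM.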

Compound 4, half-maximal cytotoxic concentration: 201000 nM
Beside the measured number, compound 4's estimate is 5.0-fold (0.70 log units) below it; measured number above the stated range.
By their numbers in this assay, from the lowest: compounds 3 and 2 (each within the scatter of the next); then compounds 1 and 4 (each within the scatter of the next).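

In this assay, this position responds to which group sits on it and not merely to whether one does: a 4.9-fold higher number from compound 2 to compound 4 (0.69 log units; beyond the scatter) runs opposite to a 3.0-fold lower number from compound 1 to compound 2 (0.48 log units; beyond the scatter). Set against the hydrogen of compound 1, methoxy gives a 1.6-fold higher number from compound 1 to compound 4 (0.22 log units; within the scatter), so of these two groups only methyl shifts the number beyond the scatter. Nothing available accounts for this difference between methyl and methoxy. Still open, going by these compounds, is how an amine or a longer chain such as ethoxy would read at this position, and whether methoxy would give the same result alongside the 2,4-dichlorophenyl of compound 3.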